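From benzyloxy to propoxy, starting at a limit

The source may hold more compounds than are shown below. What is called first, only, known or untested is meant among the compounds shown, and "the series" means these compounds.

Compound 1 `c1ccc(COc2cc(-c3ccccc3)nc3ccccc23)cc1` gives > 10 ug/mL in a functional assay on L1210 (1565) cells (Mus musculus) for cytotoxicity (a lower number here means that less compound is needed, a higher number that more compound is needed for the effect), and this is a limit of the assay and not a number. It therefore stands at the limit of > 10 ug/mL in this assay, at which 1 of the 2 values shown sits. The other measured compound, compound 2 `Oc1ccc2c(O)cc(-c3ccccc3)nc2c1`, gives a true number of 0.45 ug/mL in the same test. The open question concerns compound 3 `CCCOc1cc(-c2ccccc2)nc2ccccc12`, which keeps the shared core of compound 1 and changes only its side chain. The change is ethyl in place of phenyl on a saturated chain carbon bound to an oxygen on an aromatic ring, so that benzyloxy becomes propoxy. Within the data shown here, no measured pair of compounds shows what such a change does, and the starting point of compound 1 is only a limit. What is expected in this assay is therefore no step beyond the scatter, in neither direction, an estimated step that the limit leaves unreadable from compound 1 to compound 3. Compound 3 may well reach the limit of the assay too. For compound 3 the expected value is 12 ug/mL, with an estimated range from 3 ug/mL to 30 ug/mL.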

Compound 3, half-maximal effective concentration: > 10 ug/mL
Compound 3 gave a limit, no number (the forecaster's own chance of this, stated with the estimate: 55%); the middle value is on the limit's open side.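

In this assay compound 3 gives > 10 ug/mL, which is a limit of the assay and not a number. Compound 1 also stands at a limit, so no step can be read between compound 1 and compound 3: the limit of > 10 ug/mL in this assay, at which 2 of the 3 values shown sit. The compounds shown leave open what the change from benzyloxy to propoxy does in this assay.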